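This account rests on a few compounds, and the source may have more. Where it says the series, first, only, none or still open, it means among the compounds named here.

Measured in a functional assay on MCF7 cells (Homo sapiens) for antiproliferative activity, read by MTT assay, with a stated time of 72 h (a higher number here means a weaker inhibitor, a lower number a stronger inhibitor), each entry a limit and not a number:
- compound 1 `CCn1c(C(=O)NCc2ccc(OC)cc2)ccc1C(CC)(CC)c1ccc(C#CC(O)(CC)CC)c(C)c1` gives > 50000 nM as a limit
- compound 2 `CCn1c(C(=O)On2nnc3ccccc32)ccc1C(CC)(CC)c1ccc(C#CC(O)(CC)CC)c(C)c1` gives > 50000 nM as a limit
- compound 3 `CCn1c(C(=O)NCCC(=O)O)ccc1C(CC)(CC)c1ccc(C#CC(O)(CC)CC)c(C)c1` gives > 50000 nM as a limit

Compound 3 stands at the limit of > 50000 nM in this assay, at which 3 of the 3 values shown sit, and so offers no number to start from. Compound 4 `CCn1c(C(=O)NCCCO)ccc1C(CC)(CC)c1ccc(C#CC(O)(CC)CC)c(C)c1` differs from compound 3 by hydroxymethyl in place of carboxy on a saturated chain carbon, two bonds along the chain from an amide-type nitrogen and carries hydroxymethyl in place of carboxy, on a saturated chain carbon, two bonds along the chain from an amide-type nitrogen.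

Among the measured compounds shown here, the steps that bear on this change are a step that the two limits leave unreadable from compound 1 to compound 3 and a step that the two limits leave unreadable from compound 2 to compound 3 and also a step that the two limits leave unreadable from compound 1 to compound 2 as the remaining one in the set. None of them gives a size or a direction to carry over to this assay for this change. No step beyond the scatter is expected, and that expectation rests on compound 3 sitting at the limit of > 50000 nM in this assay, at which 3 of the 3 values shown sit, with the rest of the set. The expected step is a step that the limit leaves unreadable from compound 3 to compound 4 and a report of a limit alone is the likely outcome. The estimate for compound 4 is 60000 nM with an expected range of 20000 nM to 100000 nM around it.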

Compound 4, half-maximal inhibitory concentration: 5950 nM
For compound 4 the middle estimate is 10-fold (1.00 log units) above the measured one, outside the stated range (below it).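

In this assay, the steps among compound 1, compound 2 and compound 3 cannot be read, and the change at this position gives the first readable result in the series: hydroxymethyl in place of carboxy, on a saturated chain carbon, two bonds along the chain from an amide-type nitrogen, gives an at least 8.4-fold lower number from compound 3 to compound 4 (0.92 log units; beyond the scatter). The same side chain also separates from the other two groups on the carbonyl carbon, with an at least 8.4-fold lower number from compound 2 to compound 4 (0.92 log units; beyond the scatter) and, for 2-hydroxyethyl in place of 4-methoxyphenyl, an at least 8.4-fold lower number from compound 1 to compound 4 (0.92 log units; beyond the scatter). Compound 4 is the only compound shown with a number and not a limit: the limit of > 50000 nM in this assay, at which 3 of the 4 values shown sit.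

Going by these compounds, all three steps are set against a limit, so their full size remains open. Also open, on these data alone, is how an amine or a methyl ether in place of the hydroxyl of the 3-hydroxypropyl group, or a longer chain, would read.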